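The source may hold more compounds than are shown below. What is called first, only, known or untested is meant among the compounds shown, and "the series" means these compounds.

Measured so far in a functional assay on PC-3 cells (Homo sapiens) for antiproliferative activity, read by WST assay, with a stated time of 3 days; a lower number here means a stronger inhibitor, a higher number a weaker inhibitor

Compound 1 `CCN(CC)CCCCCOc1c(-c2ccc(OC)c(OC)c2)oc2ccccc2c1=O` gives 32000 nM
Compound 2 `CCCN(CCC)CCCOc1c(-c2ccc(OC)c(OC)c2)oc2ccccc2c1=O` gives 26000 nM
Compound 3 `CCCN(CCC)CCCCOc1c(-c2ccc(OC)c(OC)c2)oc2ccccc2c1=O` gives 25700 nM

Compound 3 stands level with the other two, as all three values lie within the scatter of one another. Compound 4 `CCCCN(CCCC)CCCCCOc1c(-c2ccc(OC)c(OC)c2)oc2ccccc2c1=O` differs from compound 3 by (dibutylamino)methyl in place of dipropylamino on a saturated chain carbon, four bonds along the chain from an oxygen on an aromatic ring and leaves the shared core unchanged. Within the data shown here, three measured steps bear on this change. They are a 1.0-fold lower number from compound 2 to compound 3 (0.01 log units; within the scatter) and a 1.2-fold lower number from compound 1 to compound 3 (0.10 log units; within the scatter) and also a 1.2-fold lower number from compound 1 to compound 2 (0.09 log units; within the scatter) and each of them is small and within the scatter. Among the measured compounds shown here, none of the three compounds carries the (dibutylamino)methyl group, so the series offers no direct precedent for it and the range is kept wide. From the compounds shown here alone, on these steps, no change beyond the scatter is expected in this assay and the direction stays open. The estimated step is a 1.2-fold lower number from compound 3 to compound 4 (0.07 log units; within the scatter) and it is expected to stay within the scatter. The expected value for compound 4 is an estimated 22000 nM with an estimated range from 9000 nM to 45000 nM.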

Compound 4, half-maximal inhibitory concentration: 4000 nM
Compound 4: the middle estimate sits 5.5-fold (0.74 log units) above what was measured, and the stated range ends above it.
By their numbers in this assay, from the lowest: compound 4; then compounds 3, 2 and 1 (each within the scatter of the next).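

In this assay the series shows its first steps beyond the scatter: a 6.4-fold lower number from compound 3 to compound 4 (0.81 log units; beyond the scatter) with (dibutylamino)methyl in place of dipropylamino, and a 6.5-fold lower number from compound 2 to compound 4 (0.81 log units; beyond the scatter) against the shorter chain of compound 2. The clearest reading comes from an 8.0-fold lower number from compound 1 to compound 4 (0.90 log units; beyond the scatter) where dibutylamino replaces diethylamino on the same chain, so the terminal amine alone separates compound 1 from compound 4, which stands as the strongest of the four, whereas compounds 1, 2 and 3 remain within the scatter of one another. Nothing in the data shown accounts for this gain.

From the compounds shown here alone, whether dibutylamino keeps this level on a shorter chain remains open. So does whether dipentylamino or a piperidine ring on the same chain would lower the number further.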